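From quinolin-6-yl to 2,3-dihydro-1,4-benzodioxin-6-yl

A few compounds are considered here, and "the series" means these few. Any claim that something is new, unique, unknown or untested is made for them only; others in the source may bear on it.

Compound 1 (`O=C1C=CC2(C=C1)OCC(=O)N2c1nc(-c2ccc3ncccc3c2)nn1-c1ccccc1`) gives 170 nM
Compound 2 (`CC1CN(c2nc(-c3ccc4ccccc4c3)nn2-c2ccccc2)C2(C=CC(=O)C=C2)O1`) gives 320 nM
Compound 3 (`CC1OC2(C=CC(=O)C=C2)N(c2nc(-c3cccc4ccccc34)nn2-c2ccccc2)C1=O`) gives 180 nM

All three values come from a functional assay on A549 cells (Homo sapiens) for antiproliferative activity, with a stated time of 5 days (a lower number here means a stronger inhibitor, a higher number a weaker inhibitor), and lie within the usual scatter of one another. Compound 3 stands nearest to compound 1, and even compound 2, the furthest from it, stays within that scatter.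

Compound 4 (`O=C1C=CC2(C=C1)OCC(=O)N2c1nc(-c2ccc3c(c2)OCCO3)nn1-c1ccccc1`) keeps the core of compound 1 and has not yet been measured. It carries 2,3-dihydro-1,4-benzodioxin-6-yl in place of quinolin-6-yl on an aromatic carbon. For the measured compounds named here, no measured pair isolates this change. Compound 2 at 320 nM and compound 3 at 180 nM carry other groups on that carbon and differ elsewhere too, yet both stay within the scatter of compound 1 at 170 nM in this comparison. A small rise in the number in this assay is therefore expected, possibly none beyond the scatter. The estimate is a 1.5-fold higher number from compound 1 to compound 4 (0.18 log units; within the scatter) as the expected step. Compound 4 is expected at 260 nM with an estimated range from 90 nM to 750 nM as its span.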

Compound 4, half-maximal inhibitory concentration: 170 nM
Compound 4: the middle estimate sits 1.5-fold (0.18 log units) above what was measured, and the stated range covers the measured number.
By their numbers in this assay, from the lowest: compounds 1, 4, 3 and 2 (each within the scatter of the next).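

In this assay, for the compounds shown here, there is no change at the digits printed from compound 1 to compound 4 (within the scatter) on exchanging quinolin-6-yl for 2,3-dihydro-1,4-benzodioxin-6-yl, and this is the first reading of a change at this aromatic carbon alone, since compound 2 and compound 3 also differ from compound 1 elsewhere. At this position, then, a six-membered aromatic ring with one hetero atom can give way to a six-membered non-aromatic ring with two hetero atoms, at the same heavy-atom count, without the number leaving the scatter. Nothing available accounts for this outcome.

As far as these compounds go, it remains open whether the position would tolerate a group of a different kind, such as a morpholine, an amine or a carboxylic acid. Also open, from the compounds shown here alone, is whether the same exchange would read alike on the cores of compound 2 and compound 3.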